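A few compounds are considered here, and "the series" means these few. Any claim that something is new, unique, unknown or untested is made for them only; others in the source may bear on it.

The shared core carries an amine nitrogen whose substituent is varied. Compound 1 `COc1cccc(NC2=CC(=O)c3c(nc4n3[C@H]3OC[C@@H](O)[C@H]3OC4)C2=O)c1` bears a 3-methoxyphenyl there, and in a functional assay on MGC-803 cells (Homo sapiens) for inhibition, read by sulforhodamine B assay (a lower number here means a stronger inhibitor, a higher number a weaker inhibitor), compound 1 gives 1790 nM. Compound 2 `Cc1ccc(NC2=CC(=O)c3nc4n(c3C2=O)[C@H]2OC[C@@H](O)[C@H]2OC4)cc1C` carries a 3,4-dimethylphenyl; in this assay compound 2 gives 860 nM, the lowest of the two numbers. Compound 3 `O=C1C(NC2CCCCC2)=CC(=O)c2c1nc1n2[C@H]2OC[C@@H](O)[C@H]2OC1` carries a cyclohexyl instead, and in this assay compound 3 reaches only the assay limit > 8000 nM. For the measured compounds named here, the one measured step, an at least 4.4-fold higher number from compound 1 to compound 3 (0.65 log units; beyond the scatter), is a clear weakening. Compound 4 `CCOc1ccc(NC2=CC(=O)c3nc4n(c3C2=O)[C@H]2OC[C@@H](O)[C@H]2OC4)cc1` keeps an aromatic ring: 4-ethoxyphenyl in place of 3,4-dimethylphenyl on an amine nitrogen. Compound 1 with 1790 nM and compound 2 with 860 nM show that such aromatic variants stay in a narrow span. Compound 4 is therefore expected to shift only slightly, a 1.4-fold higher number from compound 2 to compound 4 (0.14 log units; within the scatter). Compound 4 is estimated at 1200 nM, between 500 nM and 3500 nM.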

Compound 4, half-maximal inhibitory concentration: 1110 nM
Compound 4: middle estimate off by 1.1-fold (0.03 log units), on the high side; the range from low to high includes it.
By their numbers in this assay, from the lowest: compounds 2, 4 and 1 (each within the scatter of the next, the first and the last beyond it). At a limit, above all of these: compound 3.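

Replacing 3,4-dimethylphenyl with 4-ethoxyphenyl on the amine nitrogen brings in an oxygen and a hydrogen-bond acceptor, yet this assay shows a 1.3-fold higher number from compound 2 to compound 4 (0.11 log units; within the scatter) and so does not separate the two groups. At this position, compound 2 and compound 4 show that an ethoxy group on the aromatic ring and two methyl groups read alike. Nothing available explains this similarity. Still open, from the compounds shown here alone, is whether an amine or a carboxylic acid on the aromatic ring, or a longer chain in place of ethoxy, would read the same.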